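Moving the Ring Nitrogen in a Weak Amide Inhibitor

This account rests on a few compounds, and the source may have more. Where it says the series, first, only, none or still open, it means among the compounds named here.

Compound 1, `O=C(CCCCCCc1ccccc1)N1CCCC1`, gives 12900 nM in an assay on HEK293 cells for inhibition of N-acylethanolamine-hydrolyzing acid amidase (Rattus norvegicus), read by LC-MS, with a stated time of 30 min; a higher number here means a weaker inhibitor, a lower number a stronger inhibitor.
Compound 2, `O=C(CCc1ccc(-c2ccccc2Cl)cc1)N1CCCC1`, gives in this assay only a limit of the assay, > 100000 nM.
Compound 3, `O=C(CCCCCCc1ccccn1)N1CCCC1`, gives in this assay only a limit of the assay, > 100000 nM.

Compound 3 thus stands at the edge of what this assay can report: for compound 3 the value > 100000 nM is a limit, not a number. Two of the three values shown sit at that same limit (the limit of > 100000 nM in this assay, at which 2 of the 3 values shown sit).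

Compound 4, `O=C(CCCCCCc1cccnc1)N1CCCC1`, differs from compound 3 in one place: pyridin-3-yl in place of pyridin-2-yl on a saturated chain carbon, six bonds along the chain from a carbonyl carbon. Among the measured compounds shown here, the only measured step that bears on this change is the swap of phenyl for pyridin-2-yl, which gave an at least 7.7-fold higher number from compound 1 to compound 3 (0.88 log units; beyond the scatter). For the measured compounds named here, no measured pair shows what moving the nitrogen within the pyridine ring does, so there is no basis for expecting a shift beyond the scatter in either direction.

Compound 4 is expected to stay near the limit, estimated at 100000 nM, within 30000 nM to 300000 nM, and most likely to be reported again only as a limit. The expected step is a number no higher from compound 3 to compound 4 (the limit leaves the size open).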

Compound 4, half-maximal inhibitory concentration: > 100000 nM
Compound 4 ended at the assay's limit; the forecaster's own chance of this, stated with the estimate: 60%; the middle value sits exactly at the limit.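

Moving the ring nitrogen does not bring back what was lost with pyridin-2-yl, so that loss is not confined to a single placing of the nitrogen: in this assay there is an at least 7.7-fold higher number from compound 1 to compound 4 (0.88 log units; beyond the scatter). The step from compound 3 to compound 4 cannot be read, because both values are limits: the limit of > 100000 nM in this assay, at which 3 of the 4 values shown sit.

Any difference between the two pyridines therefore stays hidden, and among the pyridine and phenyl chain compounds only compound 1 gives a true number, 12900 nM.

On these data alone, whether pyridin-4-yl at this place would also end at the limit remains open. Also open, as far as these compounds go, is how a longer chain ending in phenyl would compare with compound 1, since a change from that compound can be read in either direction.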